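The source may hold more compounds than are shown below. What is called first, only, known or untested is meant among the compounds shown, and "the series" means these compounds.

Measured so far in this set:
Compound 1, `CCCn1c(=O)n(CCC#N)c(=O)c2[nH]cnc21` — in an assay on Cerebral cortex for binding affinity to adenosine receptor A1 (Cavia porcellus), read by radioligand binding (a lower number here means a stronger inhibitor, a higher number a weaker inhibitor), compound 1 gives 15900 nM.
Compound 2, `CCCn1c(=O)n(CCCO)c(=O)c2[nH]cnc21` — in the same assay compound 2 gives 12000 nM.

For the measured compounds named here, compound 2 has the lowest of the two numbers, but the only measured step, a 1.3-fold lower number from compound 1 to compound 2 (0.12 log units; within the scatter), lies within the scatter, so the two compounds cannot be placed in order.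

Compound 3, `CCCn1c(=O)n(CC(C)=O)c(=O)c2[nH]cnc21`, has not yet been measured. It differs from compound 2 by acetyl in place of 2-hydroxyethyl on a saturated chain carbon bound to an aromatic nitrogen. Going by the values given here, the one measured step bears on it only loosely: it also changed the end of the same chain, and it moved the number by an amount within the scatter. Among the compounds with values here, no measured step here shows a change at this chain shifting the number beyond the scatter. The step from compound 2 to compound 3 is therefore expected to be small, no change at the digits printed from compound 2 to compound 3 (within the scatter), in no clear direction. For compound 3 the estimate is 12000 nM, with a range from 4000 nM to 36000 nM.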

Compound 3, inhibition constant: 11400 nM
Beside the measured number, compound 3's estimate is 1.1-fold (0.02 log units) above it; low and high end bracket the measured number.
By their numbers in this assay, from the lowest: compounds 3, 2 and 1 (each within the scatter of the next).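

In this assay, acetyl in place of 2-hydroxyethyl on a saturated chain carbon bound to an aromatic nitrogen gives a 1.1-fold lower number from compound 2 to compound 3 (0.02 log units; within the scatter), and acetyl in place of cyanomethyl at the same place gives a 1.4-fold lower number from compound 1 to compound 3 (0.14 log units; within the scatter). So a third chain end now reads within the scatter of both others, and the hydrogen-bond donor counted in 2-hydroxyethyl but absent from acetyl leaves compound 2 and compound 3 impossible to tell apart in this assay. No evidence is available that bears on this result.

Whether any group on this chain can shift the number beyond the scatter remains open, since all three steps shown lie within it. The compounds shown also leave open what an amine, a carboxylic acid or a longer chain would do at this place.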